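Aryl swap from compound 3 to compound 4

This account rests on a few compounds, and the source may have more. Where it says the series, first, only, none or still open, it means among the compounds named here.

Compound 1 (`CC1(C)[C@H]2CC[C@]1(C)N(Cc1cn(-c3ccccc3F)nn1)C(=O)C2`) gives 300 nM
Compound 2 (`CC1(C)[C@H]2CC[C@]1(C)N(Cc1cn(-c3cccc(Br)c3)nn1)C(=O)C2`) gives 120 nM
Compound 3 (`CC1(C)[C@H]2CC[C@]1(C)N(Cc1cn(-c3ccc(Cl)cc3)nn1)C(=O)C2`) gives 410 nM

All three values come from a functional assay on SGC-7901 cells (Homo sapiens) for inhibition, read by MTT assay, with a stated time of 24 h (on this read-out lower numbers stand for stronger inhibition and higher numbers for weaker inhibition), and all three compounds share one core. Compound 3 is not separated from compound 1, since the series shows a 1.4-fold higher number from compound 1 to compound 3 (0.14 log units; within the scatter) there. Both stand weaker than compound 2, with a 2.5-fold lower number from compound 1 to compound 2 (0.40 log units; beyond the scatter) on one side and a 3.4-fold higher number from compound 2 to compound 3 (0.53 log units; beyond the scatter) on the other.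

The next compound is compound 4 (`Cc1cccc(-n2cc(CN3C(=O)C[C@@H]4CC[C@@]3(C)C4(C)C)nn2)c1`). The change is 3-methylphenyl in place of 4-chlorophenyl on an aromatic nitrogen with 3-methylphenyl in place of 4-chlorophenyl on an aromatic nitrogen.

For the measured compounds named here, no measured compound carries 3-methylphenyl, so the guidance is indirect. Going by the values given here, the most relevant comparison is a 3.4-fold higher number from compound 2 to compound 3 (0.53 log units; beyond the scatter) as compound 2 is the only measured compound whose group name also begins with 3. Reversing that step in part suggests a move towards a lower number, though three compounds support no firm pattern. Compound 1 adds little, given a 1.4-fold higher number from compound 1 to compound 3 (0.14 log units; within the scatter) as its step.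

The expected change is a 2.2-fold lower number from compound 3 to compound 4 (0.33 log units; beyond the scatter) as a modest estimated step towards a lower number. Compound 4 is estimated at 190 nM with an expected range of 80 nM to 450 nM in this assay when measured.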

Compound 4, half-maximal inhibitory concentration: 410 nM
Beside the measured number, compound 4's estimate is 2.2-fold (0.33 log units) below it, within the range that was stated.
By their numbers in this assay, from the lowest: compound 2; then compounds 1, 3 and 4 (each within the scatter of the next).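

In this assay, methyl in place of bromo on an aromatic carbon gives a 3.4-fold higher number from compound 2 to compound 4 (0.53 log units; beyond the scatter), so the 3-position label in a group name does not by itself carry the lower number: 3-methylphenyl does not share it with 3-bromophenyl. Against the other two aryl groups, the series shows no change at the digits printed from compound 3 to compound 4 (within the scatter) and a 1.4-fold higher number from compound 1 to compound 4 (0.14 log units; within the scatter), which places 3-methylphenyl with 4-chlorophenyl and 2-fluorophenyl, leaving compound 2 as the only compound separated from the rest on this read-out. No supporting data bear on the gap between 3-bromophenyl and 3-methylphenyl.

Still open, going by these compounds, is whether the lower number of compound 2 belongs to bromo specifically or would persist with 3-chlorophenyl or 3-iodophenyl, and whether it depends on where bromo sits, as 4-bromophenyl or 2-bromophenyl would show. Also open, on these data alone, is how this position responds when the phenyl ring carries an amine or a carboxylic acid, or when a longer chain joins the ring to the aromatic nitrogen.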